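The source may report more compounds than this note shows. Statements on the series, on what has been measured and on what is new or still open speak of the compounds shown alone.

Working notes on the series. Compound 1 `Cc1cccc(-c2ccccc2OC(C)C2=NCCN2)c1` and compound 2 `CC(Oc1ccccc1-c1ccccn1)C1=NCCN1` share a core and differ at one aromatic carbon. In a functional assay on CHO cells for agonist activity at Alpha-2C adrenergic receptor (Homo sapiens) (a lower number here means a smaller maximal response, a higher number a larger maximal response), compound 1 gives 0.6. Compound 2 sits at the limit of this assay, < 0.3, so only a bound is known for it, as recorded in the limit of < 0.3 in this assay, at which 1 of the 2 values shown sits. Among the measured compounds shown here, the measured step a number at least 0.30 lower from compound 1 to compound 2 (beyond the scatter) is therefore the only step available, and it runs downward to the limit. Compound 3 `CC(Oc1ccccc1-c1ccc(O)cc1)C1=NCCN1` is not yet measured; its change from compound 2 is 4-hydroxyphenyl in place of pyridin-2-yl on an aromatic carbon, restoring a carbon-only aromatic ring at the site where compound 1 carried one. For the measured compounds named here, the only comparable step is the one from compound 1 to compound 2, which was downward, so the reverse kind of change is expected to move upward rather than sit within the scatter. Compound 3 is estimated at 0.45, with a range from 0.2 to 0.7. The expected step a number at least 0.15 higher from compound 2 to compound 3 (beyond the scatter) remains uncertain since compound 2 is known only as a limit.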

Compound 3, intrinsic activity: the largest response reached, as a fraction of the reference agonist's: < 0.3
Compound 3: a limit, no number; the forecaster's own chance of this, stated with the estimate: 25%; middle value at least 0.15 away from the limit.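

In this assay compound 3 gives < 0.3, again a limit of the assay and not a number. The change to 4-hydroxyphenyl in place of 3-methylphenyl gives a number at least 0.30 lower from compound 1 to compound 3 (beyond the scatter), so at this position a ring of carbon only does not by itself carry the response seen with 3-methylphenyl. The step between the two compounds at the limit cannot be read, and the comparison of 4-hydroxyphenyl with pyridin-2-yl stays closed: the limit of < 0.3 in this assay, at which 2 of the 3 values shown sit.

The compounds shown leave open whether the loss with 4-hydroxyphenyl follows from the hydroxyl group or from the absence of the methyl group on the ring. An unsubstituted phenyl group and a 3-chlorophenyl group on the same aromatic carbon would bear on whether any response above the limit depends on the methyl group itself.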